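The source may hold more compounds than are shown below. What is called first, only, known or untested is meant among the compounds shown, and "the series" means these compounds.

The series gathers three compounds built on one shared core, a propargylamine-bearing bicyclic framework carrying a sulfur-linked aromatic substituent, all tested in an assay on isolated protein for inhibition of Amine oxidase [flavin-containing] B (Homo sapiens); a higher number here means a weaker inhibitor, a lower number a stronger inhibitor. Compound 1 `C#CCNC1CCc2c(SCc3ccc4ccccc4c3)cccc21` gives 4950 nM in this assay. Compound 3 `C#CCNC1CCc2c(SCc3ccc(F)c(F)c3)cccc21` gives 2650 nM. Compound 2 `C#CCNC1CCc2c(SCCc3ccc(C(F)(F)F)cc3)cccc21` gives 16100 nM, the highest of the three numbers: compound 1 stands nearest to it and compound 3 furthest from it, and both of those gaps lie beyond the usual scatter of repeated measurements.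

The next compound, compound 4 `C#CCNC1CCc2c(SCCc3ccc(C)cc3)cccc21`, differs from compound 2 in one place only: methyl in place of trifluoromethyl on an aromatic carbon. Among the compounds with values here, no pair among the measured compounds shares this exchange, so the three results give no direct precedent for it; the account here rests on compound 2 alone, which gives 16100 nM as its point of departure.

Since compound 2 sits at the top of the range, a change that moves compound 4 lower is expected, though of modest size, so that the step of a 2.0-fold lower number from compound 2 to compound 4 (0.30 log units; within the scatter) is estimated to be at most a little beyond the scatter. On that basis compound 4 is expected to give about 8000 nM in this assay, with a range from 2500 nM to 25000 nM.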

Compound 4, half-maximal inhibitory concentration: 25800 nM
Estimate against measurement, compound 4: 3.2-fold (0.51 log units) below; the measured number lies above the stated range.
By their numbers in this assay, from the lowest: compounds 3 and 1 (each within the scatter of the next); then compounds 2 and 4 (each within the scatter of the next).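

In this assay, the exchange of trifluoromethyl for methyl on an aromatic carbon, para to a large group, gives a 1.6-fold higher number from compound 2 to compound 4 (0.20 log units; within the scatter), so this pair offers the series' first direct reading of a change at this place. A group of four heavy atoms gives way to a group of one, neither with any hydrogen-bond donor or acceptor, and the two numbers cannot be told apart, so this exchange alone gives no measurable handle on the read-out here. Nothing among the data shown accounts for this outcome, and no measured property of either group is available to interpret it.

Still open, from the compounds shown here alone, is whether any other group at this place, such as a bare hydrogen, a chlorine, a methoxy, a nitrile, an amine or a carboxylic acid, would separate from these two compounds by more than the scatter. Also open is whether the same exchange would read the same way on a different sulfur-linked substituent, such as those of compound 1 and compound 3, since the only pair shown carries it on the substituent shared by compound 2 and compound 4.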